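Swapping the Amine Chain for Chlorine on the Shared Core

The compounds below may be only part of what the source reports. "The series", "measured", "known", "first", "only" and "open" are said of these compounds alone.

Compound 1 `Clc1ccnc2cc(OCc3ccccc3)ccc12`: 5170 nM
Compound 2 `C=CCOc1ccc2c(NCCN(C)C)ccnc2c1`: 1360 nM
Compound 3 `C=CCOc1ccc2c(NCCCN(C)C)ccnc2c1`: 6680 nM

In a functional assay on BGC-823 cells (Homo sapiens) for cytotoxicity, read by MTT assay, with a stated time of 48 h (a higher number here means a weaker inhibitor, a lower number a stronger inhibitor), compound 3 gives the highest of the three numbers. Compound 1 sits within the scatter of compound 3, whereas a 4.9-fold higher number from compound 2 to compound 3 (0.69 log units; beyond the scatter) is a modest step beyond the scatter. Compound 4 `C=CCOc1ccc2c(Cl)ccnc2c1` differs from compound 3 by chloro in place of (3-(dimethylamino)propyl)amino on an aromatic carbon. Among the compounds with values here, no measured step covers this change, so it has no direct precedent; compound 1 carries the same chloro group on its core and its number is close to that of compound 3. Compound 4 is therefore expected to stay near compound 3, with a 1.2-fold lower number from compound 3 to compound 4 (0.08 log units; within the scatter) falling within the scatter. The estimated value for compound 4 is 5500 nM, expected to lie between 2000 nM and 16000 nM.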

Compound 4, half-maximal inhibitory concentration: 2930 nM
Compound 4: middle estimate off by 1.9-fold (0.27 log units), on the high side; the measured number falls inside the stated range.
By their numbers in this assay, from the lowest: compound 2; then compounds 4, 1 and 3 (each within the scatter of the next, the first and the last beyond it).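

In this assay, chloro on the aromatic carbon opposite the ring nitrogen does not give one direction against the amine chains: replacing (3-(dimethylamino)propyl)amino gives a 2.3-fold lower number from compound 3 to compound 4 (0.36 log units; beyond the scatter), whereas replacing (2-(dimethylamino)ethyl)amino gives a 2.2-fold higher number from compound 2 to compound 4 (0.33 log units; beyond the scatter). So the outcome of this swap depends on which chain leaves. With chloro in place on both cores, vinyl in place of phenyl stays within the scatter, at a 1.8-fold lower number from compound 1 to compound 4 (0.25 log units; within the scatter), and no measurement here accounts for these results. Still open, going by these compounds, is how bromo or a longer amine chain on that carbon would compare, and whether either amine chain would behave the same on the core of compound 1.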